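Trifluoromethyl for cyano: notes on tolerated concentration

This account rests on a few compounds, and the source may have more. Where it says the series, first, only, none or still open, it means among the compounds named here.

In an ADME assay on MDCK cells (Canis lupus familiaris) for cytotoxicity, read by MTT assay, with a stated time of 24 h (a higher number here means that more compound is tolerated, a lower number that less compound is tolerated), compound 1 (`N#CCCN(Cc1cccs1)S(=O)(=O)c1ccc(C(F)(F)F)cc1`) gives > 178000 nM as a limit and not a number. Compound 2 (`N#CCCN(Cc1ccco1)S(=O)(=O)c1ccc(C#N)cc1`) also gives only a limit in this assay at > 211000 nM with no number behind it. Among the measured compounds shown here, compound 2 therefore has no exact position on the scale, and the only other measured compound is likewise a limit.

The change to compound 3 (`N#CCCN(Cc1ccco1)S(=O)(=O)c1ccc(C(F)(F)F)cc1`) is trifluoromethyl in place of cyano on an aromatic carbon in which trifluoromethyl takes the place of cyano on an aromatic carbon, para to a large group. For the measured compounds named here, no measured step is available to size this change. A shift beyond the scatter is not expected in this assay and the estimated step of an at least 1.1-fold lower number from compound 2 to compound 3 (0.05 log units; that floor lies within the scatter) is small. For compound 3 the expected value is 186000 nM with an estimated range from 100000 nM to 300000 nM and a limit is the likely report.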

Compound 3, half-maximal cytotoxic concentration: > 186000 nM
Compound 3 ended at the assay's limit; the forecaster's own chance of this, stated with the estimate: 85%; the middle value lies on the limit itself.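

Among the compounds shown here, compound 1, compound 2 and compound 3 all give only limits in this assay, and no step among them can be read. The compounds shown leave open whether trifluoromethyl in place of cyano, or furan-2-yl in place of thiophen-2-yl, shifts the tolerated concentration at all.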